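Removing the chloro group in a cytotoxicity series

The compounds below may be only part of what the source reports. "The series", "measured", "known", "first", "only" and "open" are said of these compounds alone.

Measured compounds in a functional assay on T98G cells (Homo sapiens) for cytotoxicity, read by MTT assay, with a stated time of 48 h; on this read-out higher numbers stand for weaker inhibition and lower numbers for stronger inhibition:
- compound 1 `C/C(=N/NC(=S)Nc1ccccc1Cl)c1ccccn1`: 1.1 nM
- compound 2 `C/C(=N\NC(=S)Nc1ccccc1Cl)c1ccccn1`: 1.1 nM
- compound 3 `C/C(=N\NC(=S)Nc1ccccc1I)c1ccccn1`: 8.09 nM

Compound 1 and compound 2 share all atoms and bonds and differ only in the drawn configuration of one double bond; in this assay the step of no change at the digits printed from compound 1 to compound 2 (within the scatter), consistent with the fact that compounds 1 and 2 differ only in the configuration as drawn. The two stand together at the lowest of the three numbers. Among the measured compounds shown here, the only substituent step so far is a 7.4-fold higher number from compound 2 to compound 3 (0.87 log units; beyond the scatter), a modest loss on going from chloro to iodo on the aromatic carbon.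

Compound 4 `C/C(=N/NC(=S)Nc1ccccc1)c1ccccn1` is not yet measured. It differs from compound 1 by hydrogen in place of chloro on an aromatic carbon. For the measured compounds named here, no measured step shares this change: the one substituent step runs from chloro to iodo, whereas here the chloro is taken away and only hydrogen remains at that position, ortho to a large group. The iodo step shows that the number is sensitive to what sits at this carbon, so a shift beyond the scatter is possible, most likely toward a higher number, but its size is unconstrained by the data in hand.

For compound 4 in this assay the expected step is a 2.7-fold higher number from compound 1 to compound 4 (0.44 log units; beyond the scatter), and the estimated value is 3 nM with a range from 0.7 nM to 15 nM.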

Compound 4, half-maximal inhibitory concentration: 6.81 nM
Compound 4: the middle estimate sits 2.3-fold (0.36 log units) below what was measured, and the stated range covers the measured number.
By their numbers in this assay, from the lowest: compounds 1 and 2 (each within the scatter of the next); then compounds 4 and 3 (each within the scatter of the next).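

Removing the chloro from the aromatic carbon ortho to a large group gives a 6.2-fold higher number from compound 1 to compound 4 (0.79 log units; beyond the scatter) in this assay, so the low number of compound 1 depends on the chloro itself and is not carried by the shared core alone. Until now, the only substituent step at this carbon was the exchange of one halogen for another, a 7.4-fold higher number from compound 2 to compound 3 (0.87 log units; beyond the scatter); with the hydrogen step added, both departures from chloro shown here raise the number by more than the scatter. The two steps start from the same printed number, with compound 1 at 1.1 nM and compound 2 at 1.1 nM, and can be read side by side even though they are drawn on opposite double-bond configurations, because of this: the fact that compounds 1 and 2 differ only in the configuration as drawn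

On these data alone, whether chloro is the best group at this carbon remains open, as fluoro, bromo, methyl, methoxy, an amine and a carboxylic acid would each test how narrow the preference is. Whether the drawn configuration is equally without consequence for the hydrogen and iodo compounds also remains open, as the only pair of configurations shown carries chloro.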